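Swapping cyclohexyl for isopropyl on a weakly cytotoxic ester

The compounds below may be only part of what the source reports. "The series", "measured", "known", "first", "only" and "open" are said of these compounds alone.

Among the measured compounds shown here, in a functional assay on A549 cells (Homo sapiens) for cytotoxicity, read by MTT assay, with a stated time of 48 h (a lower number here means a stronger inhibitor, a higher number a weaker inhibitor), compound 2 `C=C1C(=O)O[C@H]2CC3=C[C@H](C/C(C)=C/[C@@H](OC(=O)CC4CCCCC4)[C@H]12)OC3=O` gives 6900 nM as the only number so far. Compound 1 `C=C1C(=O)O[C@H]2CC3=C[C@H](C/C(C)=C/[C@@H](OC(=O)c4ccc([N+](=O)[O-])cc4)[C@H]12)OC3=O` sits at > 10000 nM which is a limit of the assay. Compound 3 `C=C1C(=O)O[C@H]2CC3=C[C@H](C/C(C)=C/[C@@H](OC(=O)CC(C)C)[C@H]12)OC3=O` differs from compound 2 by isopropyl in place of cyclohexyl on a saturated chain carbon bound to a carbonyl carbon in its side chain, with isopropyl in place of cyclohexyl on a saturated chain carbon bound to a carbonyl carbon. For the measured compounds named here, the only measured step bearing on this is an at least 1.4-fold lower number from compound 1 to compound 2 (0.16 log units; that floor lies within the scatter) and, resting on that limit, it fixes no size. The estimated 1.2-fold higher number from compound 2 to compound 3 (0.06 log units; within the scatter) is therefore expected to stay within the scatter, with no firm direction. Compound 3 is estimated at 8000 nM with a range of 3500 nM to 15000 nM in this assay once measured.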

Compound 3, half-maximal inhibitory concentration: 2500 nM
Compound 3: the middle estimate sits 3.2-fold (0.51 log units) above what was measured; measured number below the stated range.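

Among the compounds shown here, compound 3 gives the first step at this position that lies beyond the scatter: in this assay, isopropyl in place of cyclohexyl on a saturated chain carbon bound to a carbonyl carbon gives a 2.8-fold lower number from compound 2 to compound 3 (0.44 log units; beyond the scatter). Isobutyl in place of 4-nitrophenyl on a carbonyl carbon gives an at least 4.0-fold lower number from compound 1 to compound 3 (0.60 log units; beyond the scatter). That step is only a floor, as the value of compound 1 is a limit: the limit of > 10000 nM in this assay, at which 1 of the 3 values shown sits.

The compounds shown leave open how a shorter chain such as ethyl, or a longer chain such as n-hexyl, would compare with isobutyl. They also leave open how an amine or a carboxylic acid on this chain would read in this assay.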